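Replacing the Aryl Group on the Shared Core

This account rests on a few compounds, and the source may have more. Where it says the series, first, only, none or still open, it means among the compounds named here.

Two measured compounds share a core and differ only in one attached group. Compound 1 `Cc1cc(C#N)cc(-c2c(C)nn(-c3nc(-c4ccc(Cl)c(Cl)c4)c(SC(C)C)s3)c2C(=O)O)c1` carries a 3-cyano-5-methylphenyl group there, and in a functional assay on BJAB cells (Homo sapiens) for antiproliferative activity, with a stated time of 4 days (on this read-out lower numbers stand for an effect already at smaller amounts and higher numbers for an effect only at larger amounts of compound), compound 1 gives 4800 nM. Compound 2 `Cc1c(-c2cc(Cl)cc(Cl)c2)c(C(=O)O)nn1-c1nc(-c2cc(Cl)cc(Cl)c2)c(SC(C)C)s1` gives 2000 nM in this assay. Of the two numbers, compound 1 stands at the higher one; compound 2 is its nearest neighbour at a lower number, and that gap lies beyond the usual scatter. Among the measured compounds shown here, no single-point step between measured compounds is recorded, so the pair shows only what its two values show.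

Compound 3 `Cc1nn(-c2nc(-c3ccc(Cl)c(Cl)c3)c(SC(C)C)s2)c(C(=O)O)c1Cc1ccccc1[N+](=O)[O-]` has not yet been measured. It differs from compound 1 by 2-nitrobenzyl in place of 3-cyano-5-methylphenyl on an aromatic carbon. For the measured compounds named here, no measured pair changes this position, so the available numbers offer no guide to the size or direction of such a swap. The step expected from compound 1 to compound 3 is therefore a small one, a 1.4-fold lower number from compound 1 to compound 3 (0.14 log units; within the scatter), with no confident direction and possibly none beyond the scatter. Compound 3 is estimated at 3500 nM, within a range from 800 nM to 15000 nM.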

Compound 3, half-maximal effective concentration: 20000 nM
For compound 3 the middle estimate is 5.7-fold (0.76 log units) below the measured one; the measured number lies above the stated range.
By their numbers in this assay, from the lowest: compound 2; then compound 1; then compound 3.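

In this assay the aromatic carbon of the five-membered aromatic ring with 2 nitrogen now has a step of its own: 2-nitrobenzyl in place of 3-cyano-5-methylphenyl gives a 4.2-fold higher number from compound 1 to compound 3 (0.62 log units; beyond the scatter) and so shows that the number responds to the group at this place, with this swap moving it upward beyond the scatter. Both groups hold one six-membered aromatic ring of carbon only, so a ring of that kind at this place does not by itself keep the number where compound 1 has it, although one step cannot separate the parts of the swap, which are the benzyl link, the nitro group and the loss of the nitrile and the methyl. No measurement of any property of these groups is at hand to account for the step.

A plain benzyl group or a 2-aminobenzyl group at this carbon would be needed to tell the benzyl link apart from the nitro group, and the compounds shown contain neither. Among the compounds shown here, how a small group such as ethyl or an amine would compare here also stays open, and compound 2 differs from compound 1 in more than one place, so it offers no step at this position.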